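Growth inhibition of a silyl ether series in A2780 cells

The source may hold more compounds than are shown below. What is called first, only, known or untested is meant among the compounds shown, and "the series" means these compounds.

Measured so far in a functional assay on A2780 cells (Homo sapiens) for antiproliferative activity, read by sulforhodamine B assay, with a stated time of 48 h (on this read-out higher numbers stand for weaker inhibition of growth and lower numbers for stronger inhibition of growth), as follows

compound 1 `CC(C)(C)[Si](C)(C)O[C@H]1CCCO[C@@H]1CO` gives > 100000 nM (a limit)
compound 2 `CC(C)(C)[Si](C)(C)O[C@@H]1CCCO[C@@H]1CO` gives > 100000 nM (a limit)
compound 3 `CC(C)(C)[Si](C)(C)O[C@@H]1CCCO[C@@H]1CO/C=C/C(=O)OCc1ccccc1` gives 26000 nM (a number)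

Compound 2 stands at > 100000 nM in this assay and this is a limit, not a number. Compound 4 `CC(C)(C)[Si](C)(C)O[C@@H]1CCCO[C@@H]1CO/C=C/CO` departs from compound 2 by 3-hydroxyprop-1-en-1-yl in place of hydrogen on an oxygen on a saturated carbon with 3-hydroxyprop-1-en-1-yl in place of hydrogen on an oxygen on a saturated carbon.

Among the measured compounds shown here, the one measured step that bears on the starting point is a step that the two limits leave unreadable from compound 1 to compound 2 and it offers no size to carry forward. It rests on the fact that compounds 1 and 2 differ only in the configuration as drawn and both of its ends sit at the limit of > 100000 nM in this assay, at which 2 of the 3 values shown sit, so it says nothing about the new substituent. For the measured compounds named here, the only actual number comes from compound 3 at 26000 nM in this assay and it gives the one anchor on the scale.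

Compound 4 is therefore expected to remain weak, with at most a modest move toward stronger inhibition of growth, and a reading at the limit is quite possible. The expected change is an at least 1.6-fold lower number from compound 2 to compound 4 (0.22 log units; that floor lies within the scatter) as estimated here, and its size stays uncertain since compound 2 has no number. The estimate for compound 4 is 60000 nM (expected range 20000 nM to 150000 nM).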

Compound 4, concentration for 50% growth inhibition: > 100000 nM
Compound 4 gave a limit, no number (the forecaster's own chance of this, stated with the estimate: 45%); at least 1.6-fold (0.22 log units) between middle value and limit.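

Among the compounds shown here, compound 4 ends at a limit, not a number, just as compound 2 does, so no step from compound 2 to compound 4 can be read. The compounds shown leave open whether 3-hydroxyprop-1-en-1-yl in place of hydrogen on that oxygen changes growth inhibition at all, and if so, by how much.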